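A few compounds are considered here, and "the series" means these few. Any claim that something is new, unique, unknown or untested is made for them only; others in the source may bear on it.

Working notes on the series.

Compound 1 `Cc1ccc2nc(C(=O)Nc3c(F)cc(-c4cccc(F)c4)cc3F)c(C)c(O)c2c1` and compound 2 `Cc1c(C(=O)Nc2c(F)cc(-c3cccc(F)c3)cc2F)nc2ccc(F)cc2c1O` share one core and differ only at one aromatic carbon. In a functional assay on A-375 cells (Homo sapiens) for antiproliferative activity, read by MTT assay, with a stated time of 24 h, tested at 0.05 ug/mL (on this read-out lower numbers stand for a weaker effect and higher numbers for a stronger effect at the one concentration tested), compound 1 gives 0.96%, and compound 2 gives 0.05%. Among the compounds with values here, compound 1 stands highest of the two numbers, but the only step to it, a number 0.9 percentage points lower from compound 1 to compound 2 (within the scatter), lies within the scatter, so the two compounds cannot be placed in order; both sit at the low end of the read-out at this concentration.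

Compound 3 `Cc1c(C(=O)Nc2c(F)cc(-c3cccc(F)c3)cc2F)nc2ccc(OC(F)(F)F)cc2c1O` is not yet measured. It differs from compound 1 by trifluoromethoxy in place of methyl on an aromatic carbon. Within the data shown here, the one measured step that bears on this change is a number 0.9 percentage points lower from compound 1 to compound 2 (within the scatter), where a fluoro took the place of the same methyl on an aromatic carbon and the read-out did not move beyond the scatter. With a trifluoromethoxy entering at the same aromatic carbon, and with both measured values close to zero, no step beyond the scatter is expected in this assay; the expected step of a number 0 percentage points higher from compound 1 to compound 3 (within the scatter) is essentially flat. Compound 3 is therefore estimated at 1%, within a range from -6% to 9%.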

Compound 3, a percentage reported as inhibition, at one concentration (the size of the read-out at that concentration, not a potency): -0.13%
The estimate for compound 3 lay 1.1 percentage points above the measured number; the measured number falls inside the stated range.
By their numbers in this assay, from the lowest: compounds 3, 2 and 1 (each within the scatter of the next).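

The position on the aromatic carbon now carries three different groups in otherwise identical compounds, and none of the exchanges moves the read-out beyond the scatter. In this assay, replacing methyl with trifluoromethoxy, which brings more heavy atoms and a hydrogen-bond acceptor to this carbon, gives a number 1.1 percentage points lower from compound 1 to compound 3 (within the scatter), and replacing fluoro with the same group gives a number 0.2 percentage points lower from compound 2 to compound 3 (within the scatter), so the flat result seen with the small fluoro also holds for this larger group, and methyl, fluoro and trifluoromethoxy cannot be placed in order at the one concentration tested. No measurement at hand offers an explanation for this flat outcome.

All three values sit at the low end of the read-out, so the series does not show whether this position can affect antiproliferative activity or whether the three groups would separate under conditions that give a larger read-out. Also open, on these data alone, is how an amine, a carboxylic acid or a longer alkyl chain at this aromatic carbon would behave in this assay.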